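Replacing the methyl of compound 3 with 3-hydroxyphenyl

The source may report more compounds than this note shows. Statements on the series, on what has been measured and on what is new or still open speak of the compounds shown alone.

Compound 1 `CC(=O)c1sc(NC(C)C)c(C#N)c1N` carries a methyl on the carbonyl carbon. In an assay for inhibition of Maternal embryonic leucine zipper kinase (Homo sapiens), read by ADP-Glo, with a stated time of 0.5 h (a lower number here means a stronger inhibitor, a higher number a weaker inhibitor), compound 1 reaches only the limit > 5000 nM and gives no number. Compound 2 `CC(C)Nc1sc(C(=O)c2ccc(Br)s2)c(N)c1C#N` bears 5-bromothiophen-2-yl in place of that methyl; in this assay compound 2 gives 122 nM. Compound 3 `Cc1ccc(C(=O)c2sc(NC(C)C)c(C#N)c2N)s1` has 5-methylthiophen-2-yl there and in this assay gives 494 nM, the higher of the two numbers available; the step of a 4.0-fold higher number from compound 2 to compound 3 (0.61 log units; beyond the scatter). Both aryl groups lower the number from the limit: an at least 40-fold lower number from compound 1 to compound 2 (1.61 log units; beyond the scatter) and an at least 10-fold lower number from compound 1 to compound 3 (1.00 log units; beyond the scatter).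

Compound 4 `CC(C)Nc1sc(C(=O)c2ccc(-c3cccc(O)c3)s2)c(N)c1C#N` alters compound 3 at one place: 3-hydroxyphenyl in place of methyl on an aromatic carbon. Among the compounds with values here, only the step from compound 2 to compound 3 touches that same position, and there a swap from bromo to methyl raised the number by a modest amount; the two steps from compound 1 show that enlarging a substituent elsewhere lowered the number strongly. Within the data shown here, no step tests an aryl group at this position, so the direction is uncertain, but a modest lowering is expected, with the step of a 2.5-fold lower number from compound 3 to compound 4 (0.39 log units; beyond the scatter) estimated. For compound 4 in this assay the expected value is 200 nM, estimated between 50 nM and 800 nM.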

Compound 4, half-maximal inhibitory concentration: 350 nM
Compound 4: the middle estimate sits 1.8-fold (0.24 log units) below what was measured; measured number inside the range.
By their numbers in this assay, from the lowest: compound 2; then compounds 4 and 3 (each within the scatter of the next). At a limit, above all of these: compound 1.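

In this assay, the aromatic carbon next to the ring sulfur accepts 3-hydroxyphenyl in place of methyl with no readable change (a 1.4-fold lower number from compound 3 to compound 4 (0.15 log units; within the scatter)), although 7 heavy atoms, including a six-membered aromatic ring, enter where 1 heavy atom leaves. Bromo keeps the lowest number of the three groups tested here, since replacing it with 3-hydroxyphenyl (a 2.9-fold higher number from compound 2 to compound 4 (0.46 log units; beyond the scatter)) runs the same way as replacing it with methyl (a 4.0-fold higher number from compound 2 to compound 3 (0.61 log units; beyond the scatter)). Heavy-atom count alone therefore does not order these groups at this position, and nothing shown gives a reason for these steps.

Going by these compounds, it remains open whether the hydroxyl of 3-hydroxyphenyl contributes at all, a question that plain phenyl or 3-methoxyphenyl at this position would separate from the contribution of the ring itself. Also open, on these data alone, is whether the advantage of bromo extends to chloro or iodo on the same carbon, or to a small non-halogen group such as cyano or ethyl.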